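Methoxy on the core and a benzyl tail: an estimate

The source may hold more compounds than are shown below. What is called first, only, known or untested is meant among the compounds shown, and "the series" means these compounds.

Measured so far:
- Compound 1, `[O-][n+]1nc(NCOCc2ccccc2)[n+]([O-])c2ccccc21`: 4690 nM
- Compound 2, `CCCCCOCNc1n[n+]([O-])c2ccccc2[n+]1[O-]`: 3300 nM
- Compound 3, `CCCCCOCNc1n[n+]([O-])c2cc(OC)ccc2[n+]1[O-]`: 450 nM

In a functional assay on K562 cells (Homo sapiens) for cytotoxicity, read by MTT assay, with a stated time of 72 h (a lower number here means a stronger inhibitor, a higher number a weaker inhibitor), compound 2 gives 3300 nM and compound 1 gives 4690 nM. The change between them is phenyl in place of butyl on a saturated chain carbon bound to an oxygen on a saturated carbon and it made a 1.4-fold higher number from compound 2 to compound 1 (0.15 log units; within the scatter). The two cores differ by methoxy in place of hydrogen on an aromatic carbon, which made a 7.3-fold lower number from compound 2 to compound 3 (0.87 log units; beyond the scatter), so compound 3 has the lowest of the three numbers. Compound 4, `COc1ccc2c(c1)[n+]([O-])nc(NCOCc1ccccc1)[n+]2[O-]`, has not yet been measured. It differs from compound 3 by phenyl in place of butyl on a saturated chain carbon bound to an oxygen on a saturated carbon, the same change as from compound 2 to compound 1, at the same place. For compound 4 the step is expected to be a 1.4-fold higher number from compound 3 to compound 4 (0.15 log units; within the scatter), resting on the fact that the earlier step, a 1.4-fold higher number from compound 2 to compound 1 (0.15 log units; within the scatter), stayed within the scatter. Compound 4 is expected at 640 nM. For compound 4 the range expected is 300 nM to 1500 nM.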

Compound 4, half-maximal inhibitory concentration: 240 nM
For compound 4 the middle estimate is 2.7-fold (0.43 log units) above the measured one, outside the stated range (below it).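

In this assay, phenyl in place of butyl on the methoxy-bearing core gives a 1.9-fold lower number from compound 3 to compound 4 (0.27 log units; within the scatter), and this step does not match its counterpart on the core without methoxy: the same change on two cores in this assay, a 1.4-fold higher number (0.15 log units; within the scatter) from compound 2 to compound 1 and a 1.9-fold lower number (0.27 log units; within the scatter) from compound 3 to compound 4, 2.7-fold (0.43 log units) apart, beyond the scatter of two such steps. Methoxy in place of hydrogen gives a 20-fold lower number from compound 1 to compound 4 (1.29 log units; beyond the scatter), lowering the number with either tail but not by the same amount: the same change on two cores in this assay, a 7.3-fold lower number (0.87 log units; beyond the scatter) from compound 2 to compound 3 and a 20-fold lower number (1.29 log units; beyond the scatter) from compound 1 to compound 4, 2.7-fold (0.43 log units) apart, beyond the scatter of two such steps. So in these four compounds the direction of the methoxy step carried over and its size did not, while the two tail steps, each within the scatter, show no clear direction; this does not explain the mismatch or show that it holds beyond these compounds.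

The compounds shown leave open how a longer chain or a tail ending in an amine would behave. They also leave open whether a group such as chlorine or nitrile on the core would act as methoxy does.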